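Hydrogen for Methyl at the Ring Nitrogen: An Expected Outcome

This account rests on a few compounds, and the source may have more. Where it says the series, first, only, none or still open, it means among the compounds named here.

Compound 1 `Cn1ccc2c(Oc3ccc(NC(=O)c4cn(-c5ccc(C(F)(F)F)cc5Cl)c5ccccc5c4=O)cc3F)ccnc21` gives "not determined" (no result reported) in a functional assay on HepG2 cells (Homo sapiens) for inhibition, read by MTT assay, with a stated time of 72 h (a higher number here means a weaker inhibitor, a lower number a stronger inhibitor), so no single number is available for it there. A related compound 2 `COc1ccc(-n2cc(C(=O)Nc3ccc(Oc4ccnc5c4ccn5C)c(F)c3)c(=O)c3ccccc32)cc1`, built on the same core, is measured: in this assay compound 2 gives 3750 nM. Compound 3 `O=C(Nc1ccc(Oc2ccnc3[nH]ccc23)c(F)c1)c1cn(-c2ccc(C(F)(F)F)cc2Cl)c2ccccc2c1=O` differs from compound 1 by hydrogen in place of methyl on an aromatic nitrogen. For the measured compounds named here, no measured step of this kind is available, so the direction stays open; a change of modest size in this assay, not clearly beyond the scatter either way, is expected. For compound 3 the half-maximal inhibitory concentration is estimated at 2000 nM, within a range from 300 nM to 15000 nM.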

Compound 3, half-maximal inhibitory concentration: 1840 nM
Beside the measured number, compound 3's estimate is 1.1-fold (0.04 log units) above it; low and high end bracket the measured number.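

In this assay, for the compounds shown here, compound 1 gives "not determined" (no result reported) and compound 3 gives 1840 nM, so no step between these two compounds can be read. The compounds shown leave open how hydrogen in place of methyl on the aromatic nitrogen shifts inhibition in this assay. No evidence bears on this result.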